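Carbamate Alkyl Size and Agonist Maximal Response

The compounds below may be only part of what the source reports. "The series", "measured", "known", "first", "only" and "open" are said of these compounds alone.

Measured compounds:
compound 1 `CCOC(=O)N1CCC(Oc2ncnc(Oc3ccc(/C=C4\SC(=O)NC4=O)cc3)c2C)CC1`: 141%
compound 2 `Cc1c(Oc2ccc(/C=C3\SC(=O)NC3=O)cc2)ncnc1OC1CCN(C(=O)OCC(C)C)CC1`: 70.2%
compound 3 `CCOC(=O)N1CCC(Oc2cc(Oc3ccc(/C=C4\SC(=O)NC4=O)cc3)ncn2)CC1`: 51.8%

In a functional assay on CHO-K1 cells for agonist activity at Glucose-dependent insulinotropic receptor (Homo sapiens), read by cAMP accumulation and immunoassay, with a stated time of 1 h (a lower number here means a smaller maximal response, a higher number a larger maximal response), compound 1 gives 141%, compound 2 gives 70.2% and compound 3 gives 51.8%. Compound 3 stands lowest of the three; compound 2 is nearest to it and compound 1 furthest, both gaps lying beyond the scatter.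

Compound 4 `CC(C)(C)OC(=O)N1CCC(Oc2cc(Oc3ccc(/C=C4\SC(=O)NC4=O)cc3)ncn2)CC1` differs from compound 3 by tert-butyl in place of ethyl on an oxygen next to a carbonyl group. The step that bears on this change is a number 70.8 percentage points lower from compound 1 to compound 2 (beyond the scatter), in which a larger alkyl group on an oxygen next to a carbonyl group went with a large fall in maximal response. The step of a number 89.2 percentage points lower from compound 1 to compound 3 (beyond the scatter) concerns a methyl on an aromatic carbon and does not speak to the present change. A further fall in this assay is therefore expected for compound 4, though compound 3 already sits low and a single precedent carries limited weight. Compound 4 is estimated at 35%, with a range from 10% to 65%. The expected step is a number 16.8 percentage points lower from compound 3 to compound 4 (beyond the scatter).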

Compound 4, largest response reached (Emax), in percent of the reference or control that the assay uses: 122%
Estimate against measurement, compound 4: 87 percentage points below, outside the stated range (above it).
By their numbers in this assay, from the lowest: compound 3; then compound 2; then compound 4; then compound 1.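

In this assay, this position proved able to raise the maximal response as well as lower it: tert-butyl in place of ethyl on an oxygen next to a carbonyl group gave a number 70.2 percentage points higher from compound 3 to compound 4 (beyond the scatter) in a compound with hydrogen on the aromatic carbon. A larger alkyl group on this oxygen therefore does not in itself go with a fall, although a number 70.8 percentage points lower from compound 1 to compound 2 (beyond the scatter) had pointed that way in the methyl-bearing series. The two steps run in opposite directions, but they differ both in the alkyl group that enters and in the aromatic carbon's substituent, so neither difference can be singled out.

Still open, going by these compounds, is whether tert-butyl would raise the response with methyl on the aromatic carbon, and how a cyclopropyl group or a longer unbranched chain on the same oxygen would behave. Nothing shown here accounts for the opposite directions of these two steps.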